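This account rests on a few compounds, and the source may have more. Where it says the series, first, only, none or still open, it means among the compounds named here.

Compound 1 (`CCOC(=O)c1sc2cccc(C)c2c1Nc1cc(OC)c(OC)c(OC)c1`): 3610 nM
Compound 2 (`COC(=O)c1sc2ccccc2c1Nc1cc(OC)c(OC)c(OC)c1`): 299 nM

In a functional assay on HT-29 cells (Homo sapiens) for cytotoxicity, read by MTT assay, with a stated time of 72 h (on this read-out lower numbers stand for stronger inhibition and higher numbers for weaker inhibition), compound 2 has the lower of the two numbers, and its gap to compound 1 lies beyond the scatter. Compound 3 (`COC(=O)c1sc2cccc(C)c2c1Nc1cc(OC)c(OC)c(OC)c1`) has methyl in place of hydrogen on an aromatic carbon of compound 2: methyl in place of hydrogen on an aromatic carbon. Within the data shown here, no measured pair isolates this change. Weaker inhibition beyond the scatter is expected, resting on compound 1 at 3610 nM, the only measured compound with this methyl. The expected size is a 4.0-fold higher number from compound 2 to compound 3 (0.60 log units; beyond the scatter). For compound 3 the estimated value is 1200 nM, with an expected range of 350 nM to 4000 nM.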

Compound 3, half-maximal inhibitory concentration: 1020 nM
For compound 3 the middle estimate is 1.2-fold (0.07 log units) above the measured one, within the range that was stated.
By their numbers in this assay, from the lowest: compound 2; then compound 3; then compound 1.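

In this assay, methyl in place of hydrogen on an aromatic carbon, ortho to a fused ring, now has a measured pair of its own: a 3.4-fold higher number from compound 2 to compound 3 (0.53 log units; beyond the scatter), so the weaker inhibition no longer rests on compound 1 alone. The other side of the molecule also gains a reading: hydrogen in place of methyl on a saturated chain carbon bound to an oxygen next to a carbonyl group gives a 3.5-fold lower number from compound 1 to compound 3 (0.55 log units; beyond the scatter). Open: whether methoxy or chlorine on that aromatic carbon behaves like methyl, and whether a carboxylic acid can replace the ester. Nothing at hand bears on the cause of either step.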